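Growing the Acyl Chain on a Bicyclic Amine Core

The compounds below may be only part of what the source reports. "The series", "measured", "known", "first", "only" and "open" are said of these compounds alone.

Measured compounds:
compound 1, `CCC(=O)N1CC2CC(C1)N2` — 6 nM
compound 2, `CC(C)C(=O)N1CC2CC(C1)N2` — 130 nM
compound 3, `O=C(C1CCC1)N1CC2CC(C1)N2` — 16 nM

All three compounds share the same core and differ only in the group attached to the carbonyl. In an assay on SH-EP1 cells for displacement of a labelled ligand from Neuronal acetylcholine receptor; alpha4/beta2 (Homo sapiens), read by scintillation counting (on this read-out higher numbers stand for weaker inhibition and lower numbers for stronger inhibition), compound 1 gives the lowest number of the three, so it is the strongest binder in this small set. Its nearest neighbour is compound 3, reached by the step of a 2.7-fold higher number from compound 1 to compound 3 (0.43 log units; beyond the scatter). The furthest is compound 2, reached by the step of a 22-fold higher number from compound 1 to compound 2 (1.34 log units; beyond the scatter).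

Compound 4, `O=C(CC1C=CCC1)N1CC2CC(C1)N2`, is the next compound in line. Relative to compound 1 the change is cyclopent-2-en-1-yl in place of methyl on a saturated chain carbon bound to a carbonyl carbon. Among the measured compounds shown here, two measured steps bear on this. The step of a 22-fold higher number from compound 1 to compound 2 (1.34 log units; beyond the scatter) shows that adding a carbon to the saturated chain carbon next to the carbonyl costs a great deal, and the step of a 2.7-fold higher number from compound 1 to compound 3 (0.43 log units; beyond the scatter) shows that a ring in the acyl group also costs, though less. Compound 4 places a much larger ring-bearing group on that same chain carbon, so a weaker binding is expected, perhaps in between those two steps; the estimated step is a 6.7-fold higher number from compound 1 to compound 4 (0.82 log units; beyond the scatter). For compound 4 the estimate in this assay is therefore 40 nM, with a likely range from 8 nM to 200 nM.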

Compound 4, inhibition constant: 53 nM
Compound 4: the middle estimate sits 1.3-fold (0.12 log units) below what was measured; the measured number falls inside the stated range.
By their numbers in this assay, from the lowest: compound 1; then compound 3; then compound 4; then compound 2.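

The earlier compounds shown here changed the group on the carbonyl carbon or put a methyl in place of a hydrogen, whereas here the methyl of compound 1 itself gives way to cyclopent-2-en-1-yl, a group of 5 carbons with one ring and one double bond. In this assay, this swap on a saturated chain carbon bound to a carbonyl carbon gives an 8.8-fold higher number from compound 1 to compound 4 (0.95 log units; beyond the scatter), so the larger group costs binding strength, yet compound 4 still reads 53 nM and does not lose binding altogether. No supporting measurement is available to explain this loss.

This single swap brings in added carbons, a ring and a double bond all at once, so the compounds shown cannot separate the contribution of each. A saturated cyclopentyl group would test the double bond, an open pentyl chain would test the ring, and a phenyl ring or a chain ending in an amine would show whether this position accepts groups of a different kind.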